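Two Fluorine Placements, One Swap at the Sulfonyl Aryl

The source may hold more compounds than are shown below. What is called first, only, known or untested is meant among the compounds shown, and "the series" means these compounds.

Compound 1, `N#Cc1ccc(S(=O)(=O)N2C/C(=C\c3ccccc3F)C(=O)/C(=C/c3ccccc3F)C2)cc1`, gives 11000 nM in an ADME assay on L02 cells (Homo sapiens) for cytotoxicity, read by MTT assay, with a stated time of 24 h; on this read-out lower numbers stand for stronger inhibition and higher numbers for weaker inhibition.
Compound 2, `CC(=O)Nc1ccc(S(=O)(=O)N2C/C(=C\c3ccccc3F)C(=O)/C(=C/c3ccccc3F)C2)cc1`, gives 11500 nM in this assay.
Compound 3, `N#Cc1ccc(S(=O)(=O)N2C/C(=C\c3cccc(F)c3)C(=O)/C(=C/c3cccc(F)c3)C2)cc1`, gives 15500 nM in this assay.

From compound 1 to compound 2 the change is acetamido in place of cyano on an aromatic carbon, and the step it made was a 1.0-fold higher number from compound 1 to compound 2 (0.02 log units; within the scatter). Compound 3 differs from compound 1 in its core; that difference is not broken down here, and the two values lie within the usual scatter of each other. Compound 4, `CC(=O)Nc1ccc(S(=O)(=O)N2C/C(=C\c3cccc(F)c3)C(=O)/C(=C/c3cccc(F)c3)C2)cc1`, is not yet measured. It arises from compound 3 by acetamido in place of cyano on an aromatic carbon, the same change seen from compound 1 to compound 2. Because that earlier step was a 1.0-fold higher number from compound 1 to compound 2 (0.02 log units; within the scatter), the step from compound 3 to compound 4 in this assay is expected to be about as small, a 1.0-fold higher number from compound 3 to compound 4 (0.01 log units; within the scatter). Compound 4 is therefore estimated at 16000 nM, likely between 8000 nM and 32000 nM.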

Compound 4, half-maximal inhibitory concentration: 17500 nM
Estimate against measurement, compound 4: 1.1-fold (0.04 log units) below; measured number inside the range.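

The swap of cyano for acetamido again leaves the number in this assay within the usual scatter, with a 1.1-fold higher number from compound 3 to compound 4 (0.05 log units; within the scatter). The change therefore reads alike on the two cores shown: the same change on two cores in this assay, a 1.0-fold higher number (0.02 log units; within the scatter) from compound 1 to compound 2 and a 1.1-fold higher number (0.05 log units; within the scatter) from compound 3 to compound 4, 1.1-fold (0.03 log units) apart, within the scatter of two such steps. Within the data shown here, this shows that, on these two cores and in this one assay, the change produces no step that stands out from the scatter, but it does not show that the same would hold on any other core or in any other assay.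

Still open, from the compounds shown here alone, is whether another group on the same aromatic carbon, such as an amine or a carboxylic acid, would give a step beyond the scatter. Also open, going by these compounds, is how the number would read with chlorine in place of each fluorine.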